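Replacing the indolyl amine in the weakest compound of the series

The source may report more compounds than this note shows. Statements on the series, on what has been measured and on what is new or still open speak of the compounds shown alone.

Compound 1 `COc1ccc(-c2nc(C(=O)/C=C\Nc3ccc4[nH]ccc4c3)c3ccccn23)cc1`: 5120 nM
Compound 2 `COc1ccc(-c2nc(C(=O)/C=C\Nc3ccc(Cl)cc3)c3ccccn23)cc1`: 1240 nM
Compound 3 `O=C(/C=C\Nc1ccc2[nH]ccc2c1)c1nc(-c2ccc(C(F)(F)F)cc2)n2ccccc12`: 18200 nM

These three enaminone compounds were measured in a functional assay on B16-F10 cells (Mus musculus) for cytotoxicity, read by MTT assay, with a stated time of 48 h; on this read-out higher numbers stand for weaker inhibition and lower numbers for stronger inhibition. Compound 3 stands at the top of the three numbers, with compound 1 the nearest to it and compound 2 the furthest away. The move from compound 3 to compound 4 `COc1ccc(N/C=C\C(=O)c2nc(-c3ccc(C(F)(F)F)cc3)n3ccccc23)cc1` is 4-methoxyphenyl in place of 1H-indol-5-yl on an amine nitrogen. The step that bears on this is a 4.1-fold lower number from compound 1 to compound 2 (0.62 log units; beyond the scatter), which also swaps the indolyl group on the amine nitrogen for a phenyl carrying one substituent, and gave a modest drop in the number. Among the compounds with values here, no measured pair shows 4-methoxyphenyl against 1H-indol-5-yl on that nitrogen, so the size of the effect of the methoxy group on this ring is uncertain. Compound 4 is therefore expected to give a modestly lower number than compound 3, the step of a 2.6-fold lower number from compound 3 to compound 4 (0.41 log units; beyond the scatter) being the estimate. The estimated value for compound 4 is 7000 nM, within a range from 2500 nM to 20000 nM.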

Compound 4, half-maximal inhibitory concentration: > 30000 nM
Compound 4: no number, only a limit; the forecaster's own chance of this, stated with the estimate: 5%; at least 4.2-fold (0.63 log units) between middle value and limit.
By their numbers in this assay, from the lowest: compound 2; then compound 1; then compound 3. At a limit, above all of these: compound 4.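

In this assay, the step on the amine nitrogen reads an at least 1.6-fold higher number from compound 3 to compound 4 (0.21 log units; that floor lies within the scatter); its floor alone does not separate the two compounds, but the reading for compound 4 is a limit of the assay and not a number: the limit of > 30000 nM in this assay, at which 1 of the 4 values shown sits. The earlier step on this nitrogen, a 4.1-fold lower number from compound 1 to compound 2 (0.62 log units; beyond the scatter), went the other way, so a phenyl carrying one substituent in place of 1H-indol-5-yl does not lower the number in every case shown. Compound 4 is the one that goes against that earlier step, and it shows that the outcome on this nitrogen depends on more than the loss of 1H-indol-5-yl.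

The compounds shown leave open whether the difference between these two steps lies with the substituent on the phenyl or with the trifluoromethyl and methoxy groups elsewhere on the compounds. They also leave open how a phenyl bearing an amine or a carboxylic acid would read on this nitrogen.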